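The source may hold more compounds than are shown below. What is called first, only, known or untested is meant among the compounds shown, and "the series" means these compounds.

Compound 1 `NC1=NC2(CCSCC2)N(OCCCOc2ccc(Br)cc2)C(N)=N1`: 740 nM
Compound 2 `NC1=NC2(CCOCC2)N(OCCCOc2cccc(Cl)c2Cl)C(N)=N1`: 100 nM
Compound 3 `NC1=NC2(CCSCC2)N(OCCCOc2cc(Cl)c(Cl)cc2Cl)C(N)=N1`: > 100000 nM (a limit of the assay)

In a functional assay on A549 cells (Homo sapiens) for antiproliferative activity, read by MTT assay, with a stated time of 72 h (a lower number here means a stronger inhibitor, a higher number a weaker inhibitor), compound 2 gives the lowest of the two numbers; compound 1 gives 740 nM. Compound 3 is reported only as a limit, > 100000 nM. Going by the values given here, the single measured step, an at least 130-fold higher number from compound 1 to compound 3 (2.13 log units; beyond the scatter), is large, and it runs into (the limit of > 100000 nM in this assay, at which 1 of the 3 values shown sits). Compound 4 `NC1=NC2(CCOCC2)N(OCCCOc2ccc(Br)cc2)C(N)=N1` differs from compound 2 by 4-bromophenyl in place of 2,3-dichlorophenyl on an oxygen on a saturated carbon. Among the compounds with values here, no measured step covers this change on the core of compound 2, so the expectation leans on compound 1, which carries the same 4-bromophenyl on a different core and gives 740 nM. Compound 4 is therefore expected to show a 7.0-fold higher number from compound 2 to compound 4 (0.85 log units; beyond the scatter), a weakening beyond the scatter. The estimate for compound 4 is 700 nM, within 150 nM to 3000 nM.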

Compound 4, half-maximal inhibitory concentration: 280 nM
Compound 4: middle estimate off by 2.5-fold (0.40 log units), on the high side; measured number inside the range.
By their numbers in this assay, from the lowest: compound 2; then compound 4; then compound 1. At a limit, above all of these: compound 3.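

With the core held fixed, 4-bromophenyl in place of 2,3-dichlorophenyl gives a 2.8-fold higher number from compound 2 to compound 4 (0.45 log units; beyond the scatter) in this assay, so the two groups differ only modestly on this core. The same 4-bromophenyl gives compound 1 740 nM and compound 4 280 nM, so the numbers also differ with the core. Nothing available explains the step between the two groups. Still open, going by these compounds, is how a phenyl ring carrying a single chlorine, an amine or a carboxylic acid would compare with compound 2 on this core.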